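A Side-Chain Removal Tested Against a Histone Acetyltransferase

A few compounds are considered here, and "the series" means these few. Any claim that something is new, unique, unknown or untested is made for them only; others in the source may bear on it.

Measured compounds, in an assay for inhibition of histone acetyltransferase KAT2B (Homo sapiens), read by TR-FRET, with a stated time of 10 min, tested at 50 uM; a lower number here means less inhibition, a higher number more inhibition at the concentration tested (going by the name of the read-out):
compound 1 `Cc1cccc(NC(=O)CN2C(=O)/C(=C3\SC(=S)N(CCS(=O)(=O)O)C3=O)c3ccccc32)c1`: 6%
compound 2 `COC(=O)CCN1C(=O)/C(=C/c2cc(OC)ccc2OC)SC1=S`: 8%
compound 3 `O=C(O)CCCCCN1C(=O)/C(=C/c2ccc(-c3ccccc3)cc2)SC1=S`: < 5% (a limit of the assay)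

All three values lie low. Compound 1 and compound 2 sit within the usual scatter of each other, so nothing separates them. Compound 3 gives only a limit of the assay, as the limit of < 5% in this assay, at which 1 of the 3 values shown sits, records.

The piece follows compound 1 to compound 4 `O=C1Nc2ccccc2/C1=C1/SC(=S)N(CCS(=O)(=O)O)C1=O`, not yet measured in this assay. The change is hydrogen in place of ((3-methylphenyl)carbamoyl)methyl on an amide-type nitrogen in a ring. No measured step matches this change, and no compound shown departs from the low values seen here. Compound 4 is therefore expected to stay in the same low region, with a step of no change at the digits printed from compound 1 to compound 4 (within the scatter), none beyond the scatter. The estimate for compound 4 is 6%, between 0% and 15%.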

Compound 4, a percentage reported as inhibition, at one concentration (the size of the read-out at that concentration, not a potency): < 5%
Compound 4: no number, only a limit; the forecaster's own chance of this, stated with the estimate: 35%; middle value at least 1 percentage points away from the limit.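

In this assay, the first step read at this position, hydrogen in place of ((3-methylphenyl)carbamoyl)methyl on the amide-type nitrogen gives a number at least 1 percentage points lower from compound 1 to compound 4 (that floor lies within the scatter), so removing this group reveals no effect beyond the scatter. Compound 4 gives < 5%, which is a limit of the assay. Compound 4 therefore adds a second compound at this limit: the limit of < 5% in this assay, at which 2 of the 4 values shown sit.

The compounds shown do not tell whether an amine or a carboxylic acid on a longer chain at this nitrogen would change inhibition beyond the scatter. They also leave open whether ((3-methylphenyl)carbamoyl)methyl matters on a core with higher inhibition.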